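Sulfonate ester series: methyl to fluoro on compound 3

The compounds below may be only part of what the source reports. "The series", "measured", "known", "first", "only" and "open" are said of these compounds alone.

Measured in an ADME assay on HEK-293T cells (Homo sapiens) for inhibition, read by CCK-8 assay, with a stated time of 48 h, tested at 20 uM (a higher number here means more inhibition of growth at the concentration tested, a lower number less inhibition of growth), so far:
compound 1 `COc1ccc(Cc2nnc(NC(=O)/C(C#N)=C/c3ccccc3OS(=O)(=O)c3ccc(C)cc3)s2)cc1` gives 21%
compound 2 `Cc1ccc(S(=O)(=O)Oc2ccccc2/C=C(\C#N)C(=O)Nc2nnc(Cc3ccccc3)s2)cc1` gives 15%
compound 3 `Cc1ccc(S(=O)(=O)Oc2ccccc2/C=C(\C#N)C(=O)Nc2nnc(Cc3ccc(F)cc3)s2)cc1` gives 16%

All three values lie within the scatter of each other. Compound 3, at 16%, cannot be separated from the other two: the gaps are a number 1 percentage points higher from compound 2 to compound 3 (within the scatter) and a number 5 percentage points lower from compound 1 to compound 3 (within the scatter).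

The next compound is compound 4 `N#C/C(=C\c1ccccc1OS(=O)(=O)c1ccc(F)cc1)C(=O)Nc1nnc(Cc2ccc(F)cc2)s1`. Its difference from compound 3 is fluoro in place of methyl on an aromatic carbon. This is fluoro in place of methyl on an aromatic carbon, para to a large group, which also reads as 4-methylphenyl to 4-fluorophenyl.

Among the measured compounds shown here, no measured step touches this place, so the evidence is indirect. For the measured compounds named here, the nearest precedent is the entry of fluoro elsewhere, a number 1 percentage points higher from compound 2 to compound 3 (within the scatter). The remaining changes at that same end, a number 6 percentage points lower from compound 1 to compound 2 (within the scatter) and a number 5 percentage points lower from compound 1 to compound 3 (within the scatter), also stay within the scatter. None of these shows how this assay responds to a change at the methyl group, and no step beyond the scatter has yet been seen in the series.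

The estimated step is a number 1 percentage points higher from compound 3 to compound 4 (within the scatter), and it is not expected to exceed the scatter. For compound 4 the expected value is 17%, with an estimated range of 7% to 30%.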

Compound 4, percent growth inhibition at one concentration: "not toxic" (no number reported)
Compound 4: no number reported; there is nothing to compare the estimate with.
By their numbers in this assay, from the lowest: compounds 2, 3 and 1 (each within the scatter of the next).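

In this assay, among the compounds shown here, compound 4 is reported only as "not toxic", without a number, so no step from compound 3 to compound 4 can be read. Nothing at hand bears on this result. Still open, from the compounds shown here alone, is whether 4-fluorophenyl in place of 4-methylphenyl changes growth inhibition, and whether any change exceeds the scatter.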